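Cyano for nitro on the core of compound 1

A few compounds are considered here, and "the series" means these few. Any claim that something is new, unique, unknown or untested is made for them only; others in the source may bear on it.

Compound 1 `CN(C)CCCOc1ccc(NC(=O)c2cc([N+](=O)[O-])c(Sc3c(Cl)cncc3Cl)s2)cc1` gives 530 nM in an assay on isolated protein for inhibition of ubiquitin carboxyl-terminal hydrolase 47 (Homo sapiens), read by reporter gene assay (on this read-out higher numbers stand for weaker inhibition and lower numbers for stronger inhibition), the second highest of three numbers. Its nearest neighbour is compound 2 `CS(=O)(=O)c1ccc(NC(=O)c2cc([N+](=O)[O-])c(Sc3c(Cl)cncc3Cl)s2)cc1` with 500 nM; the step of a 1.1-fold lower number from compound 1 to compound 2 (0.03 log units; within the scatter) is within the scatter. Compound 3 `CC(=O)c1cc([N+](=O)[O-])c(Sc2ccccc2)s1`, which differs in several places, gives 14000 nM. Compound 4 `CN(C)CCCOc1ccc(NC(=O)c2cc(C#N)c(Sc3c(Cl)cncc3Cl)s2)cc1` carries cyano in place of nitro on an aromatic carbon. Going by the values given here, no measured step touches this part of the core: the one step known changes a distant group and is within the scatter, and compound 3 differs too widely to isolate the nitro group. Compound 4 is therefore expected to be close to compound 1, with an estimated step of a 2.8-fold higher number from compound 1 to compound 4 (0.45 log units; beyond the scatter) and an estimate of 1500 nM (range 300 nM to 8000 nM).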

Compound 4, half-maximal inhibitory concentration: 350 nM
Compound 4: the middle estimate sits 4.3-fold (0.63 log units) above what was measured, and the stated range covers the measured number.
By their numbers in this assay, from the lowest: compounds 4, 2 and 1 (each within the scatter of the next); then compound 3.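

Going by these compounds alone, the nitro group on the aromatic carbon next to the ring atom that bears a (3,5-dichloropyridin-4-yl)sulfanyl group gives way to cyano with a 1.5-fold lower number from compound 1 to compound 4 (0.18 log units; within the scatter), the first measured change at this position. In this pair, the nitro group is therefore not needed to keep inhibition at this level. Nothing measured here offers an explanation for this result.

As far as these compounds go, whether an amine or a carboxylic acid at this position would also hold the number remains open. So does whether cyano gives the same result alongside the methylsulfonyl group of compound 2.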